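Working notes: hydrazone aryl exchange in the series

A few compounds are considered here, and "the series" means these few. Any claim that something is new, unique, unknown or untested is made for them only; others in the source may bear on it.

Compound 2 `CN(C(=O)NC(=O)c1ccc(C(F)(F)F)cc1)c1nc(C(F)(F)F)c(C(=O)N/N=C/c2cccc(C(F)(F)F)c2)s1` gives 1.84 ug/mL in a functional assay on BCG823 cells (Homo sapiens) for inhibition, read by MTT assay, with a stated time of 72 h (on this read-out higher numbers stand for weaker inhibition and lower numbers for stronger inhibition), and holds the lowest number of the two measured compounds. Within the data shown here, compound 1 `CN(C(=O)NC(=O)c1c(F)cccc1F)c1nc(C(F)(F)F)c(C(=O)N/N=C/c2cccc(C(F)(F)F)c2)s1` gives 25.9 ug/mL in this assay; the single measured step, a 14-fold lower number from compound 1 to compound 2 (1.15 log units; beyond the scatter), sits on the carbonyl carbon, where 4-(trifluoromethyl)phenyl replaces 2,6-difluorophenyl. Compound 3 `CN(C(=O)NC(=O)c1ccc(C(F)(F)F)cc1)c1nc(C(F)(F)F)c(C(=O)N/N=C/c2ccccc2C(F)(F)F)s1` keeps that carbonyl part of compound 2 and differs only at the carbon with a double bond to nitrogen, where the change is 2-(trifluoromethyl)phenyl in place of 3-(trifluoromethyl)phenyl on a carbon with a double bond to nitrogen. Among the measured compounds shown here, no measured step touches this place; the step from compound 1 to compound 2 concerns a different carbonyl group and gives no guide to how the carbon double-bonded to nitrogen answers to a rearranged trifluoromethyl on its phenyl. With no comparison at that place, the expected step of a 1.0-fold higher number from compound 2 to compound 3 (0.01 log units; within the scatter) is none beyond the scatter, with a wide allowance in both directions. Compound 3 is therefore expected to give about 1.9 ug/mL in this assay, with a range from 0.6 ug/mL to 6 ug/mL.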

Compound 3, half-maximal inhibitory concentration: 2.53 ug/mL
Compound 3: the middle estimate sits 1.3-fold (0.12 log units) below what was measured, and the stated range covers the measured number.
By their numbers in this assay, from the lowest: compounds 2 and 3 (each within the scatter of the next); then compound 1.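

At the carbon with a double bond to nitrogen, the series now has its first measured comparison: 2-(trifluoromethyl)phenyl in place of 3-(trifluoromethyl)phenyl gives a 1.4-fold higher number from compound 2 to compound 3 (0.14 log units; within the scatter). In this assay, compound 2 and compound 3 therefore cannot be told apart, so this rearrangement of the trifluoromethyl on the phenyl leaves the read-out within the scatter, whereas the change on the carbonyl carbon gave a 14-fold lower number from compound 1 to compound 2 (1.15 log units; beyond the scatter). Nothing measured here offers an explanation of this result, and no independent data bear on it.

As far as these compounds go, it remains open how this place answers to a larger change, such as a plain phenyl without the trifluoromethyl or a phenyl carrying an amine or a carboxylic acid, since the two groups compared here have the same atoms and differ only in how they are joined. From the compounds shown here alone, it is also open whether compound 2 and compound 3 would stay within the scatter of each other with 2,6-difluorophenyl on the carbonyl carbon, the group of compound 1, which gives 25.9 ug/mL.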